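The compounds below may be only part of what the source reports. "The series", "measured", "known", "first", "only" and "open" are said of these compounds alone.

Measured in a functional assay on NCI-H1299 cells (Homo sapiens) for inhibition, read by CCK-8 assay, with a stated time of 72 h, tested at 10 uM; on this read-out higher numbers stand for more inhibition of growth at the one concentration tested and lower numbers for less inhibition of growth:

Compound 1 `CN(C)C(=O)c1cc2cnc(Nc3ccc(N)cn3)nc2n1C1CCCC1`: 82.1%
Compound 2 `CN(C)C(=O)c1cc2cnc(Nc3ccc(NC(=O)C4(C(=O)Nc5cccc(O)c5)CC4)cc3)nc2n1C1CCCC1`: 78.5%
Compound 3 `Nc1ccc(NC(=O)C2(C(=O)Nc3ccc(F)cc3)CC2)cc1F`: 59.2%

In this assay, compound 2 gives 78.5%. This lies within the usual scatter of compound 1 at 82.1%. Compound 2 stands beyond the scatter above compound 3, which gives 59.2%.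

The account now turns to compound 4 `CN(C)C(=O)c1cc2cnc(Nc3ccc(NC(=O)C4(C(=O)Nc5ccc(Cl)c(C(F)(F)F)c5)CC4)cc3)nc2n1C1CCCC1`, which has not yet been measured. It carries 4-chloro-3-(trifluoromethyl)phenyl in place of 3-hydroxyphenyl on an amide-type nitrogen. For the measured compounds named here, no measured pair of compounds isolates this change or any other single change, so the expectation rests on indirect evidence. Compound 1 and compound 2 share a core but differ widely in what is attached to it, and compound 1 at 82.1% and compound 2 at 78.5% still lie within the scatter of each other. Compound 4 keeps that same core, so no step beyond the scatter is expected in this assay, and any shift is expected to be slightly downward. The estimated change is a number 2.5 percentage points lower from compound 2 to compound 4 (within the scatter). The estimate for compound 4 is 76%, with an expected range from 56% to 93%.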

Compound 4, percent growth inhibition at one concentration: 90.4%
Compound 4: the middle estimate sits 14.4 percentage points below what was measured; the measured number falls inside the stated range.
By their numbers in this assay, from the lowest: compound 3; then compounds 2, 1 and 4 (each within the scatter of the next, the first and the last beyond it).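

In this assay, for the compounds shown here, placing 4-chloro-3-(trifluoromethyl)phenyl instead of 3-hydroxyphenyl on the amide-type nitrogen gives a number 11.9 percentage points higher from compound 2 to compound 4 (beyond the scatter) and is the first change in a single place that can be read. It shows that the group on this nitrogen can move growth inhibition beyond the usual scatter, even though the step is modest, and that a high value here does not depend on the hydrogen-bond donor of 3-hydroxyphenyl, since the group that enters has none. No supporting measurement is available to explain why this exchange raises the number.

The chlorine and the trifluoromethyl group arrive together, so the compounds shown leave open whether either one alone would account for the step, as a phenyl ring carrying only chlorine or only trifluoromethyl could tell, and whether an amine or a carboxylic acid on that ring would be tolerated. They also leave open whether the step would hold across a range of concentrations, as this read-out rests on a single one.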